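The source may hold more compounds than are shown below. What is called first, only, known or untested is meant among the compounds shown, and "the series" means these compounds.

Measured compounds:

Compound 1 `Cc1ccc(C)c(-n2nncc2CN2C(=O)C3(C(C#N)=C(N)Oc4c3c3nc5ccccc5nc3c3ccccc43)c3ccccc32)c1`: in an ADME assay on L02 cells (Homo sapiens) for antiproliferative activity, read by MTT assay, with a stated time of 48 h (on this read-out lower numbers stand for stronger inhibition and higher numbers for weaker inhibition), compound 1 gives > 50000 nM, which is a limit of the assay and not a number.

Compound 2 `Cc1cc(C)cc(-n2nncc2CN2C(=O)C3(C(C#N)=C(N)Oc4c3c3nc5ccccc5nc3c3ccccc43)c3ccccc32)c1`: in this assay compound 2 gives > 50000 nM, again a limit of the assay.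

Compound 3 `Cc1ccc(C)c(-n2nncc2CN2C(=O)C3(C(C#N)=C(N)Oc4c(N)cc5nc6ccccc6nc5c43)c3ccccc32)c1`: in this assay compound 3 gives > 50000 nM, also a limit of the assay.

The unmeasured compound is compound 4 `Cc1cc(C)cc(-n2nncc2CN2C(=O)C3(C(C#N)=C(N)Oc4c(N)cc5nc6ccccc6nc5c43)c3ccccc32)c1`. Compound 1 and compound 2 differ by one change, (3,5-dimethylphenyl in place of 2,5-dimethylphenyl on an aromatic nitrogen), and the step it made is a step that the two limits leave unreadable from compound 1 to compound 2. Because both values sit at the limit of > 50000 nM in this assay, at which 3 of the 3 values shown sit, the size of that step cannot be read. Compound 3 carries a different core from compound 1; the difference between the two cores is not broken down here. Compound 4 stands to compound 3 as compound 2 stands to compound 1: the change 3,5-dimethylphenyl in place of 2,5-dimethylphenyl on an aromatic nitrogen is the same change made on the core of compound 3, since the surroundings of the place are described in the same words for both pairs.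

With all three measured values resting at the limit of > 50000 nM in this assay, at which 3 of the 3 values shown sit, the step from compound 3 to compound 4 is expected to be a step that the limit leaves unreadable from compound 3 to compound 4 in this assay, that is, no readable movement, as compound 3 itself gives only > 50000 nM. Compound 4 is therefore expected to give about 70000 nM in this assay, with a range from 25000 nM to 250000 nM, and most likely only a limit will be reported.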

Compound 4, half-maximal inhibitory concentration: > 50000 nM
Compound 4: no number, only a limit; the forecaster's own chance of this, stated with the estimate: 85%; the middle value lies beyond the limit too.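

The step from compound 3 to compound 4 cannot be read, and neither can the matching step from compound 1 to compound 2, because every value here is a limit of the assay and not a number: the limit of > 50000 nM in this assay, at which 4 of the 4 values shown sit.

The compounds shown leave open whether 3,5-dimethylphenyl in place of 2,5-dimethylphenyl makes any difference in this assay on either core, and what concentration of any of the four compounds would reach half-maximal inhibition.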